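Replacing an aromatic amine substituent with a short dialkylamine

A few compounds are considered here, and "the series" means these few. Any claim that something is new, unique, unknown or untested is made for them only; others in the source may bear on it.

Two compounds share a core and differ only in the group attached to a nitrogen on the aromatic ring. Compound 1, `CC(C(=O)NCc1ccc(C(F)(F)F)nc1NC1CCCCC1)c1ccc(NS(C)(=O)=O)c(F)c1`, carries a cyclohexyl there, and in a functional assay on CHO-K1 cells for antagonist activity at transient receptor potential cation channel subfamily V member 1 (Homo sapiens), read by FLIPR (on this read-out higher numbers stand for weaker inhibition and lower numbers for stronger inhibition), compound 1 gives 260 nM. Compound 2, `CC(C(=O)NCc1ccc(C(F)(F)F)nc1NCc1ccc(Cl)cc1)c1ccc(NS(C)(=O)=O)c(F)c1`, carries a 4-chlorobenzyl instead, and in this assay compound 2 gives 414 nM. The step of a 1.6-fold higher number from compound 1 to compound 2 (0.20 log units; within the scatter) shows that these two groups behave alike. Within the data shown here, compound 2 has the highest of the two numbers, but its only neighbour, compound 1, lies within the scatter, so no ranking can be drawn.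

Compound 3, `CCCCN(C)c1nc(C(F)(F)F)ccc1CNC(=O)C(C)c1ccc(NS(C)(=O)=O)c(F)c1`, goes further: butyl(methyl)amino in place of (4-chlorobenzyl)amino on an aromatic carbon. Among the measured compounds shown here, the only measured step that touches this position, a 1.6-fold higher number from compound 1 to compound 2 (0.20 log units; within the scatter), swapped one bulky group for another without moving the number. For the measured compounds named here, no measured step removes the hydrogen-bond donor or shortens the group to an open chain, so the expectation for compound 3 rests on a weak basis. A modest step in this assay is expected, a 1.4-fold higher number from compound 2 to compound 3 (0.16 log units; within the scatter), towards weaker inhibition. Compound 3 is therefore estimated at 600 nM, with a range from 200 nM to 1800 nM.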

Compound 3, half-maximal inhibitory concentration: 21.3 nM
Compound 3: the middle estimate sits 28-fold (1.45 log units) above what was measured; measured number outside the range, below it.
By their numbers in this assay, from the lowest: compound 3; then compounds 1 and 2 (each within the scatter of the next).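

In this assay, the step of a 19-fold lower number from compound 2 to compound 3 (1.29 log units; beyond the scatter) and the step of a 12-fold lower number from compound 1 to compound 3 (1.09 log units; beyond the scatter) both lie beyond the scatter, so the group on this aromatic carbon, next to the ring nitrogen, can strongly change inhibition even though compound 1 and compound 2 alone gave no sign of it. Butyl(methyl)amino is the only group shown here that gives such a low number, and it differs from (4-chlorobenzyl)amino in more than one way: it has no ring, fewer heavy atoms and no hydrogen-bond donor, so this single swap changes several features together. No evidence is available to show which of these differences produces the stronger inhibition.

The compounds shown leave open whether butylamino, which keeps the hydrogen on the nitrogen, would give a number close to that of compound 3 or closer to those of compound 1 and compound 2. They also leave open whether the open chain matters, a question that dimethylamino, dipropylamino or a closed ring such as piperidin-1-yl at the same carbon could help to answer.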